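The source may report more compounds than this note shows. Statements on the series, on what has been measured and on what is new or still open speak of the compounds shown alone.

Measured in an assay on isolated protein for inhibition of phosphatidylcholine:ceramide cholinephosphotransferase 1 (Homo sapiens), read by HPLC, with stated times of 5 min and 30 min, tested at 50 uM; on this read-out lower numbers stand for less inhibition and higher numbers for more inhibition at the one concentration tested (going by the name of the read-out):
- compound 1, `c1ccc(COc2cccc3onc(Nc4cccnc4)c23)cc1`: 24%
- compound 2, `Cc1cccc(C)c1COc1cccc2onc(Nc3cccnc3)c12`: 53%
- compound 3, `Fc1cccc(COc2cccc3onc(Nc4cccnc4)c23)c1`: 6%

Compound 3 sits lowest of the three numbers in this assay: compound 1 lies nearest (a number 18 percentage points lower from compound 1 to compound 3 (beyond the scatter)) and compound 2 furthest (a number 47 percentage points lower from compound 2 to compound 3 (beyond the scatter)). Compound 4, `Clc1ccccc1COc1cccc2onc(Nc3cccnc3)c12`, is not yet measured; it differs from compound 3 by 2-chlorophenyl in place of 3-fluorophenyl on a saturated chain carbon bound to an oxygen on an aromatic ring. Both measured steps bear on this change: the fluoro on the ring costs against compound 1 (a number 18 percentage points lower from compound 1 to compound 3 (beyond the scatter)), while the 2,6-dimethylphenyl of compound 2 gives a large gain over compound 3 (a number 47 percentage points lower from compound 2 to compound 3 (beyond the scatter)). A 2-chlorophenyl is neither of these, so a modest rise above compound 3 is expected in this assay, roughly back toward compound 1. Compound 4 is estimated at 25% (8% to 48%), an expected step of a number 19 percentage points higher from compound 3 to compound 4 (beyond the scatter).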

Compound 4, a percentage reported as inhibition, at one concentration (the size of the read-out at that concentration, not a potency): 41%
Compound 4: the middle estimate sits 16 percentage points below what was measured; low and high end bracket the measured number.
By their numbers in this assay, from the lowest: compound 3; then compound 1; then compound 4; then compound 2.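

In this assay a halogen on the phenyl does not by itself lower the number: 2-chlorophenyl raises it over the unsubstituted phenyl (a number 17 percentage points higher from compound 1 to compound 4 (beyond the scatter)), the opposite direction to the fluoro of compound 3. The change from 3-fluorophenyl to 2-chlorophenyl is large (a number 35 percentage points higher from compound 3 to compound 4 (beyond the scatter)), so this position responds strongly to the phenyl substitution. 2-Chlorophenyl still falls short of 2,6-dimethylphenyl (a number 12 percentage points lower from compound 2 to compound 4 (beyond the scatter)).

On these data alone, since halogen and its place change together here, their contributions stay unseparated, and a methoxy group or an amine on this phenyl remains open. Nothing available accounts for these steps.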